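The compounds below may be only part of what the source reports. "The series", "measured", "known", "first", "only" and "open" are said of these compounds alone.

Compound 1 `CCN(CC)CCNC(=O)c1ccc(C(CC)(CC)c2ccc(OCC(O)C(C)(C)C)c(C)c2)n1CC` gives 690 nM in a functional assay on MCF7 cells (Homo sapiens), read by MTT assay, with a stated time of 48 h; on this read-out higher numbers stand for weaker inhibition and lower numbers for stronger inhibition. Compound 2 `CCn1c(C(=O)NCC(OC)OC)ccc1C(CC)(CC)c1ccc(OCC(O)C(C)(C)C)c(C)c1` stands in this assay only at a limit, > 50000 nM, so it is the weaker of the two measured compounds without an exact figure. Among the measured compounds shown here, the one measured step, an at least 72-fold higher number from compound 1 to compound 2 (1.86 log units; beyond the scatter), is large, toward weaker inhibition, and ends at the limit of > 50000 nM in this assay, at which 1 of the 2 values shown sits. Compound 3 `CCn1c(C(=O)Oc2ccc(CCO)cc2)ccc1C(CC)(CC)c1ccc(OCC(O)C(C)(C)C)c(C)c1` differs from compound 2 by a group of 10 heavy atoms (8 carbon, 2 oxygen; one six-membered aromatic ring of carbon only) in place of a group of 7 heavy atoms (4 carbon, 1 nitrogen, 2 oxygen; no ring), on a carbonyl carbon. For the measured compounds named here, no measured step covers this change itself, and compound 3, like compound 2, lacks the (diethylamino)methyl group of compound 1, so little recovery is expected. Compound 3 is expected at 30000 nM, between 5000 nM and 100000 nM, an expected step of an at least 1.6-fold lower number from compound 2 to compound 3 (0.22 log units; that floor lies within the scatter).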

Compound 3, half-maximal inhibitory concentration: > 50000 nM
Compound 3 ended at the assay's limit; the forecaster's own chance of this, stated with the estimate: 50%; middle value at least 1.6-fold (0.22 log units) from the limit.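

In this assay, a second, quite different group on the carbonyl carbon, this one holding a six-membered aromatic ring of carbon only, also gives a limit and not a number, and the change from the group of compound 1 is an at least 72-fold higher number from compound 1 to compound 3 (1.86 log units; beyond the scatter). The step between compound 2 and compound 3 cannot be read, as both values are limits: the limit of > 50000 nM in this assay, at which 2 of the 3 values shown sit.

The compounds shown leave open whether the value of compound 1 depends on its diethylamino group specifically. A dimethylamino or piperidine group on the same chain, or a longer chain carrying the diethylamino group, could settle that.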